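A few compounds are considered here, and "the series" means these few. Any claim that something is new, unique, unknown or untested is made for them only; others in the source may bear on it.

Compound 1, `Cc1cc(C)cc(Cn2c(=O)cc(NC3CC3)n(Cc3ccccc3)c2=O)c1`, was tested in an ADME assay on MT4 cells (Homo sapiens) for cytotoxicity, read by MTT assay, with a stated time of 4 days (on this read-out higher numbers stand for lower toxicity in this test and lower numbers for higher toxicity in this test), and there compound 1 gives > 100000 nM, which is a limit of the assay rather than a number. Compound 2, `Cc1cc(C)cc(Cn2c(=O)cc(N)n(CC#N)c2=O)c1`, likewise gives only a limit in this assay, namely > 100000 nM. Both readings share (the limit of > 100000 nM in this assay, at which 2 of the 2 values shown sit), so neither compound has shown toxicity that the assay can register. Compound 3, `Cc1cc(C)cc(Cn2c(=O)cc(N3CCNCC3)n(Cc3ccccc3)c2=O)c1`, differs from compound 1 by piperazin-1-yl in place of cyclopropylamino on an aromatic carbon. Within the data shown here, with no measured step to lean on, no change beyond the usual scatter is expected in this assay. The expected step is a step that the limit leaves unreadable from compound 1 to compound 3. Compound 3 is therefore estimated at 150000 nM, within a range from 60000 nM to 400000 nM, most likely reported again only as a limit.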

Compound 3, half-maximal cytotoxic concentration: 16000 nM
Compound 3: the middle estimate sits 9.4-fold (0.97 log units) above what was measured; the whole stated range lies above it.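

Compound 3 is the first compound shown to give a real number in this assay, so a change at this aromatic carbon can bring toxicity into the range the test registers. Piperazin-1-yl in place of cyclopropylamino gives an at least 6.2-fold lower number from compound 1 to compound 3 (0.79 log units; beyond the scatter), and here a lower number means higher toxicity in this test. That size is only a minimum, because compound 1 stands at a limit: the limit of > 100000 nM in this assay, at which 2 of the 3 values shown sit.

The compounds shown leave open whether the second nitrogen of piperazin-1-yl matters or the six-membered ring alone is enough. A piperidin-1-yl or morpholin-4-yl group on this carbon would help separate the two.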